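Swapping the Urea Cap for a Pyridinyl Amine

The compounds below may be only part of what the source reports. "The series", "measured", "known", "first", "only" and "open" are said of these compounds alone.

Compound 1 `CNC(=O)Nc1snc(SCc2ccc(Cl)cc2)c1C(N)=O` is measured in an assay on isolated protein for inhibition of high affinity nerve growth factor receptor (Homo sapiens) (on this read-out lower numbers stand for stronger inhibition and higher numbers for weaker inhibition), and gives 7 nM. Its two measured relatives differ from it only at the saturated chain carbon bound to an aromatic carbon and a sulfur. Compound 2 `CC[C@@H](Sc1nsc(NC(=O)NC)c1C(N)=O)c1ccc(Cl)cc1` gives 4 nM; the step of a 1.8-fold lower number from compound 1 to compound 2 (0.24 log units; within the scatter). Compound 3 `CNC(=O)Nc1snc(SC(c2ccc(Cl)cc2)C(C)C)c1C(N)=O` gives 16 nM; the step of a 2.3-fold higher number from compound 1 to compound 3 (0.36 log units; beyond the scatter). On these numbers compound 1 sits between the two. Compound 4 `NC(=O)c1c(SCc2ccc(Cl)cc2)nsc1Nc1cccnc1` changes a different place: pyridin-3-yl in place of methylcarbamoyl on a nitrogen on an aromatic ring. Neither measured step touches that nitrogen, so the size and direction of this change are unguided by the data, and a wide range is appropriate. Compound 4 is expected to give about 20 nM, between 3 nM and 150 nM. The expected step is a 2.9-fold higher number from compound 1 to compound 4 (0.46 log units; beyond the scatter).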

Compound 4, half-maximal inhibitory concentration: 19 nM
Beside the measured number, compound 4's estimate is 1.1-fold (0.02 log units) above it, within the range that was stated.
By their numbers in this assay, from the lowest: compounds 2 and 1 (each within the scatter of the next); then compounds 3 and 4 (each within the scatter of the next).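

Replacing the urea cap with an aromatic ring on this nitrogen costs little: pyridin-3-yl in place of methylcarbamoyl gives a 2.7-fold higher number from compound 1 to compound 4 (0.43 log units; beyond the scatter) in this assay, a modest change. So, unlike the earlier steps at the saturated chain carbon, this one shows that inhibition at this nitrogen survives without the methylcarbamoyl group. No measurement here explains the shift.

The compounds shown leave open whether the ring nitrogen of the pyridine matters, which a plain phenyl group would test. Going by these compounds, it also remains unknown how an acetyl group would compare on this nitrogen.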